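This account rests on a few compounds, and the source may have more. Where it says the series, first, only, none or still open, it means among the compounds named here.

In a functional assay (thoracic aorta) with Oryctolagus cuniculus as the target (on this read-out higher numbers stand for weaker inhibition and lower numbers for stronger inhibition), the three measured compounds gave:

Compound 1 `CC1=Nc2cc(=O)n(Cc3ccccc3)n2C(c2cccc([N+](=O)[O-])c2)/C1=C(/O)OC(C)C`: 5 nM
Compound 2 `CC1=Nc2cc(=O)n(C(=O)c3ccccc3)n2C(c2cccc([N+](=O)[O-])c2)/C1=C(/O)OC(C)C`: 54 nM
Compound 3 `CCCNC(=O)n1c(=O)cc2n1C(c1cccc([N+](=O)[O-])c1)/C(=C(/O)OC(C)C)C(C)=N2`: 23 nM

Compound 3 stands second highest of the three: compound 2 gives a higher number and compound 1 a lower one, both beyond the scatter. Compound 4 `CC1=Nc2cc(=O)n(S(=O)(=O)c3ccccc3)n2C(c2cccc([N+](=O)[O-])c2)/C1=C(/O)OC(C)C` is not yet measured; it differs from compound 3 by phenylsulfonyl in place of propylcarbamoyl on an aromatic nitrogen. Among the measured compounds shown here, two measured steps bear on this. In the step of a 2.3-fold lower number from compound 2 to compound 3 (0.37 log units; beyond the scatter) a phenyl gave way to propylamino and the number fell modestly; compound 4 brings a phenyl back into the side group. In the step of an 11-fold higher number from compound 1 to compound 2 (1.03 log units; beyond the scatter) benzyl gave way to benzoyl and the number rose sharply. A modest rise is therefore expected, a 2.2-fold higher number from compound 3 to compound 4 (0.34 log units; beyond the scatter). Compound 4 is estimated at 50 nM, between 15 nM and 160 nM.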

Compound 4, half-maximal inhibitory concentration: 10 nM
Compound 4: middle estimate off by 5.0-fold (0.70 log units), on the high side, outside the stated range (below it).
By their numbers in this assay, from the lowest: compounds 1 and 4 (each within the scatter of the next); then compound 3; then compound 2.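

On this aromatic nitrogen in this assay, a phenyl ring in the side group does not by itself bring a high number: phenylsulfonyl in place of benzoyl gives a 5.4-fold lower number from compound 2 to compound 4 (0.73 log units; beyond the scatter) and so the link to the ring matters. Phenylsulfonyl in place of propylcarbamoyl gives a 2.3-fold lower number from compound 3 to compound 4 (0.36 log units; beyond the scatter) as well, while the step of a 2.0-fold higher number from compound 1 to compound 4 (0.30 log units; within the scatter) leaves phenylsulfonyl and benzyl indistinguishable here. Nothing measured here gives a reason for these differences. As far as these compounds go, whether methylsulfonyl, or a phenylsulfonyl ring carrying an amine or a carboxylic acid, would fit this position equally well stays open.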